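The source may report more compounds than this note shows. Statements on the series, on what has been measured and on what is new or still open speak of the compounds shown alone.

In an ADME assay on microsomes from liver (Rattus norvegicus) for metabolic stability, read by LC-MS, with a stated time of 10 min, tested at 0.5 uM (a lower number here means that less of the compound is left, a higher number that more of the compound is left), three compounds sharing one core have been measured. Compound 1 `c1ccc2c(c1)CN[C@@H](CN(CCCN1CCNCC1)[C@H]1CCCc3cccnc31)C2` gives 100%, compound 2 `c1ccc2c(c1)CN[C@@H](CN(CCC1CCNCC1)[C@H]1CCCc3cccnc31)C2` gives 17%, and compound 3 `c1ccc2c(c1)CN[C@@H](CN(CCN1CCNCC1)[C@H]1CCCc3cccnc31)C2` gives 62%. Compound 3 therefore holds the middle place of the three, and its gaps to both of the others lie beyond the scatter.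

Compound 4 `CN1CCN(CCCN(C[C@H]2Cc3ccccc3CN2)[C@H]2CCCc3cccnc32)CC1` differs from compound 3 in one place: (4-methylpiperazin-1-yl)methyl in place of piperazin-1-yl on a saturated chain carbon, two bonds along the chain from an amine nitrogen. In words, (4-methylpiperazin-1-yl)methyl stands in place of piperazin-1-yl on a saturated chain carbon, two bonds along the chain from an amine nitrogen. Cut one bond further out, the change reads 2-(piperazin-1-yl)ethyl to 3-(4-methylpiperazin-1-yl)propyl.

The closest guide is the large step of a number 38 percentage points lower from compound 1 to compound 3 (beyond the scatter), which swaps (piperazin-1-yl)methyl for piperazin-1-yl. Compound 4 runs the opposite way on that part of the change, which points upward. The large step of a number 45 percentage points higher from compound 2 to compound 3 (beyond the scatter) shows how far this read-out can move with a single change at this place. Among the measured compounds shown here, no measured compound carries the 4-methyl part of the new group, so only part of the rise is counted on, and the range stays wide.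

The expected change is a moderate rise, an estimated step of a number 13 percentage points higher from compound 3 to compound 4 (beyond the scatter). The estimate for compound 4 is 75%, with an expected range from 45% to 100%.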

Compound 4, percent of the compound remaining: 10%
Compound 4: middle estimate off by 65 percentage points, on the high side, outside the stated range (below it).
By their numbers in this assay, from the lowest: compounds 4 and 2 (each within the scatter of the next); then compound 3; then compound 1.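

Compared with compound 1, methyl in place of hydrogen on an amine nitrogen in a ring gives a number 90 percentage points lower from compound 1 to compound 4 (beyond the scatter) in this assay, so the chain of compound 1 does not keep the compound intact on its own. The whole change gives a number 52 percentage points lower from compound 3 to compound 4 (beyond the scatter) even though compound 4 has the longer chain, which means that the higher number of compound 1 over compound 3 does not carry over once this methyl is present. The step of a number 7 percentage points lower from compound 2 to compound 4 (within the scatter) leaves (4-methylpiperazin-1-yl)methyl and piperidin-4-yl indistinguishable in this read-out, although the two groups differ in both ring and chain.

On these data alone, it remains open whether the same methyl would have so large an effect on the shorter chain of compound 3, and whether an ethyl or an acetyl on that ring nitrogen would behave like the methyl. Nothing available here explains why a single methyl on that nitrogen goes with so large a step.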